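This account rests on a few compounds, and the source may have more. Where it says the series, first, only, none or still open, it means among the compounds named here.

Compound 1 `Fc1cccc(Nc2nc(-c3cccc(F)c3)nc3ccc(F)cc23)c1` in a functional assay on MDA-MB-231 cells (Homo sapiens) for cytotoxicity, read by MTT assay, with a stated time of 48 h; on this read-out lower numbers stand for stronger inhibition and higher numbers for weaker inhibition: 47600 nM.
Compound 2 `Fc1cccc(-c2nc(Nc3cccc(Br)c3)c3cc(F)ccc3n2)c1` in this assay: > 50000 nM, a limit.
Compound 3 `Oc1ccc(Nc2nc(-c3cccc(F)c3)nc3ccc(F)cc23)cc1` in this assay: > 50000 nM, a limit.

Compound 3 thus sits at the limit of > 50000 nM in this assay, at which 2 of the 3 values shown sit, alongside compound 2, while compound 1 alone gives a number. Compound 4 `Oc1cccc(Nc2nc(-c3cccc(F)c3)nc3ccc(F)cc23)c1` differs from compound 3 by 3-hydroxyphenyl in place of 4-hydroxyphenyl on a nitrogen on an aromatic ring. For the measured compounds named here, two measured steps touch the same nitrogen: an at least 1.0-fold higher number from compound 1 to compound 3 (0.02 log units; that floor lies within the scatter) supplies only a floor that lies within the scatter, and a step that the two limits leave unreadable from compound 2 to compound 3 is unreadable. Neither gives a reason to expect a shift beyond the scatter in this assay in either direction, and with compound 3 itself at a limit the size of any move is open. Compound 4 is therefore estimated to stay near the limit, at 50000 nM with a range of 20000 nM to 120000 nM, which means an expected step of a number no higher from compound 3 to compound 4 (the limit leaves the size open).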

Compound 4, half-maximal inhibitory concentration: > 50000 nM
Compound 4: only a limit was reported; the forecaster's own chance of this, stated with the estimate: 65%; the middle value sits exactly at the limit.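

In this assay the 3-hydroxyphenyl of compound 4, like the 4-hydroxyphenyl of compound 3, ends at a limit, so moving the hydroxy on this nitrogen-linked ring yields no number: the limit of > 50000 nM in this assay, at which 3 of the 4 values shown sit.

For the compounds shown here, the steps between two limits cannot be read, and the one readable step is an at least 1.0-fold higher number from compound 1 to compound 4 (0.02 log units; that floor lies within the scatter). Going from the fluoro to the hydroxy thus gives only that floor.

Going by these compounds, the true values behind these limits stay open, as does how an amine or a carboxylic acid in place of the hydroxy would read.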